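A few compounds are considered here, and "the series" means these few. Any claim that something is new, unique, unknown or untested is made for them only; others in the source may bear on it.

Measured compounds in an assay on isolated protein for inhibition of kallikrein-7 (Homo sapiens), read by fluorescence, with stated times of 10 min and 30 min; on this read-out lower numbers stand for stronger inhibition and higher numbers for weaker inhibition:
- compound 1 `Cc1cccc(C)c1CC1CN/C(=N\N(C)C)CN(CC(=O)Nc2cccc(-c3cnn(C)c3)c2)C1=O`: 5200 nM
- compound 2 `CN(C)/N=C1/CN(CC(=O)Nc2cccc(-c3cnn(C)c3)c2)C(=O)C(Cc2c(Cl)cccc2Cl)CN1`: 790 nM; > 30000 nM; 380 nM (3 entries)
- compound 3 `Cc1cccc(F)c1CC1CN/C(=N\N(C)C)CN(CC(=O)Nc2cccc(-c3cnn(C)c3)c2)C1=O`: 2300 nM

Compound 3 holds the lowest of the two single numbers in this assay. Its nearest neighbour is compound 1, and the step of a 2.3-fold lower number from compound 1 to compound 3 (0.35 log units; beyond the scatter) lies beyond the scatter. Compound 2 has no single number: among its several entries the several entries of compound 2 in this assay, 790 nM; > 30000 nM; 380 nM (3 entries) one is a limit of the assay, and the remaining two are spread, so compound 2 gives no firm anchor.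

Compound 4 `CN(C)/N=C1/CN(CC(=O)Nc2cccc(-c3cnn(C)c3)c2)C(=O)C(Cc2c(F)cccc2C(F)(F)F)CN1` differs from compound 3 in one place: trifluoromethyl in place of methyl on an aromatic carbon. Going by the values given here, no measured step swaps methyl for trifluoromethyl on this ring. Among the compounds with values here, the only measured change at this ring, fluoro in place of methyl a 2.3-fold lower number from compound 1 to compound 3 (0.35 log units; beyond the scatter), was modest, and the change now in question is of a different kind, so it offers only an indication of the scale such a replacement can reach here.

On that basis compound 4 is expected to land near compound 3, with the step of a 1.2-fold lower number from compound 3 to compound 4 (0.06 log units; within the scatter) estimated to stay within or just beyond the scatter. The estimate for compound 4 is 2000 nM, with a range from 700 nM to 6000 nM.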

Compound 4, half-maximal inhibitory concentration: 2700 nM
For compound 4 the middle estimate is 1.4-fold (0.13 log units) below the measured one; measured number inside the range.
By their numbers in this assay, from the lowest: compounds 3, 4 and 1 (each within the scatter of the next, the first and the last beyond it).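

In this assay the step of a 1.2-fold higher number from compound 3 to compound 4 (0.07 log units; within the scatter) stays within the scatter, so trifluoromethyl in place of methyl on this aromatic carbon, with 4 heavy atoms entering where 1 leaves, gives no readable change. The step of a 1.9-fold lower number from compound 1 to compound 4 (0.28 log units; within the scatter) also stays within the scatter, which leaves 2-fluoro-6-(trifluoromethyl)phenyl not separable from 2,6-dimethylphenyl on this read-out, even though the step of a 2.3-fold lower number from compound 1 to compound 3 (0.35 log units; beyond the scatter) lies beyond it. Going by these compounds alone, the earlier compounds showed only a swap of methyl for fluoro on this ring, whereas this result shows that the position also takes a larger group with the number held within the scatter of compound 3, so among compounds 1, 3 and 4 the only step beyond the scatter remains the fluoro one.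

On these data alone, whether a group of another kind on this aromatic carbon, such as an amine, a carboxylic acid or a longer chain, would move the number stays open. Compound 2 offers no firm reference for this ring, since one of its entries is a limit of the assay and the other two are spread: the several entries of compound 2 in this assay, 790 nM; > 30000 nM; 380 nM (3 entries)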